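The source may hold more compounds than are shown below. What is called first, only, known or untested is meant among the compounds shown, and "the series" means these compounds.

Working notes on the series, taken in an assay on isolated protein for binding affinity to sphingosine 1-phosphate receptor 2 (Homo sapiens), read by surface plasmon resonance; a higher number here means weaker binding, a lower number tighter binding.

Of the compounds shown here, two have numbers so far. Compound 1 `COc1cc(NC(=O)NNc2cc(-c3ccccc3)c3cnn(C)c3n2)cc(Cl)n1` gives 3640 nM in this assay. Compound 2 `Cn1nc(C(F)(F)F)c2c(-c3ccccc3)cc(NNC(=O)Nc3cc(Cl)nc(Cl)c3)nc21` gives 940 nM in this assay; this is the lowest of the two numbers, and the gap to compound 1 is beyond the scatter. The two differ in more than one place, so nothing can be read from that pair about a single change.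

Compound 3 `Cn1ncc2c(-c3ccccc3)cc(NNC(=O)Nc3cc(Cl)nc(Cl)c3)nc21` has not yet been measured. It differs from compound 2 in one place: hydrogen in place of trifluoromethyl on an aromatic carbon, on an aromatic carbon of a five-membered aromatic ring with two nitrogen, part of a fused or bridged system of two rings. Within the data shown here, no measured pair isolates this change, so the expectation rests on compound 2 alone. Compound 1, which also carries hydrogen at this carbon, is weaker, but its other differences leave the cause open.

A small loss of affinity is expected, of about a 1.9-fold higher number from compound 2 to compound 3 (0.28 log units; within the scatter). Compound 3 is estimated at 1800 nM in this assay, with a range from 700 nM to 5000 nM.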

Compound 3, dissociation constant: 1020 nM
Compound 3: middle estimate off by 1.8-fold (0.25 log units), on the high side, within the range that was stated.
By their numbers in this assay, from the lowest: compounds 2 and 3 (each within the scatter of the next); then compound 1.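

In this assay, the step of a 1.1-fold higher number from compound 2 to compound 3 (0.04 log units; within the scatter) shows that trifluoromethyl and hydrogen cannot be told apart at this aromatic carbon of the five-membered ring, so the four heavy atoms of trifluoromethyl are not needed to hold affinity in this pair. The step of a 3.6-fold lower number from compound 1 to compound 3 (0.55 log units; beyond the scatter) isolates a second place for the first time, and chloro in place of methoxy on an aromatic carbon is the only single change shown here that lies beyond the scatter, though it is modest. Nothing measured bears on the reason for either step.

With only hydrogen and trifluoromethyl shown at the first carbon, it remains open whether a methyl group, an amine or a carboxylic acid there would also leave the affinity within the scatter of these two. As far as these compounds go, at the second place, only chloro and methoxy are compared, on a core with hydrogen at the first carbon, so it remains open how a nitrile or an amine would read there and whether the chloro and methoxy step would carry over with trifluoromethyl present.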